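The source may report more compounds than this note shows. Statements on the series, on what has been measured and on what is new or still open speak of the compounds shown alone.

For the measured compounds named here, compound 3 `CCn1c(C(=O)NC(CC(=O)O)C(=O)OC)ccc1C(CC)(CC)c1ccc(OCCC(O)(CC)CC)c(C)c1` gives the lowest number of the three measured so far in an assay on cells for agonist activity at vitamin D3 receptor (Homo sapiens), with a stated time of 96 h; a higher number here means that more compound is needed for the effect, a lower number that less compound is needed: compound 3 gives 26 nM. Compound 2 `CCn1c(C(=O)N(C)CC(=O)O)ccc1C(CC)(CC)c1ccc(OCCC(O)(CC)CC)c(C)c1` gives 89 nM, and compound 1 `C#CC(C)OC(=O)c1ccc(C(CC)(CC)c2ccc(OCCC(O)(CC)CC)c(C)c2)n1CC` gives 2650 nM. The step of a 100-fold lower number from compound 1 to compound 3 (2.01 log units; beyond the scatter) and the step of a 30-fold lower number from compound 1 to compound 2 (1.47 log units; beyond the scatter) are both large; the step of a 3.4-fold lower number from compound 2 to compound 3 (0.53 log units; beyond the scatter) is modest.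

Compound 4 `CCn1c(C(=O)NC(C)CO)ccc1C(CC)(CC)c1ccc(OCCC(O)(CC)CC)c(C)c1` is to be measured in this assay. Its change from compound 3 is a group of 4 heavy atoms (3 carbon, 1 oxygen; no ring) in place of a group of 9 heavy atoms (5 carbon, 4 oxygen; no ring), on an amide-type nitrogen. The measured step that bears most directly on it is the modest one, a 3.4-fold lower number from compound 2 to compound 3 (0.53 log units; beyond the scatter), which trades one amide substituent for another; the two large steps alter the carbonyl carbon itself and do not map onto this change. A modest step toward a higher number is therefore expected, since compound 4 keeps the amide-type nitrogen of compound 3 but carries a smaller group on it, of the kind that gave compound 2 its 89 nM. Compound 4 is expected to give 100 nM, with a range from 25 nM to 400 nM. The step of a 3.8-fold higher number from compound 3 to compound 4 (0.59 log units; beyond the scatter) is the expected outcome.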

Compound 4, half-maximal effective concentration: 96 nM
Estimate against measurement, compound 4: 1.0-fold (0.02 log units) above; low and high end bracket the measured number.
By their numbers in this assay, from the lowest: compound 3; then compounds 2 and 4 (each within the scatter of the next); then compound 1.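

In this assay the step of a 28-fold lower number from compound 1 to compound 4 (1.44 log units; beyond the scatter) shows that the advantage over the ester of compound 1 does not depend on a carboxylic acid, which compound 2 and compound 3 carry and compound 4 lacks. The step of a 1.1-fold higher number from compound 2 to compound 4 (0.03 log units; within the scatter) stays within the scatter, so 1-(hydroxymethyl)ethyl on the amide-type nitrogen cannot be told apart from the substituents of compound 2 in this read-out. The step of a 3.7-fold higher number from compound 3 to compound 4 (0.57 log units; beyond the scatter) leaves the larger group of compound 3, with its carboxylic acid and methyl ester, as the only amide substituent here that stands clear of both others.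

As far as these compounds go, whether the hydroxyl of compound 4 contributes at all stays open, and an isopropyl group or an aminoethyl chain in its place on the nitrogen would address that. No data are available that explain the differences among these substituents.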